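Aryl changes on the shared core and lipophilicity

The source may hold more compounds than are shown below. What is called first, only, known or untested is meant among the compounds shown, and "the series" means these compounds.

Measured so far in a physicochemical assay for lipophilicity (a higher number here means a more lipophilic compound, a lower number a more polar compound), for three compounds:
- compound 1 `C[C@H]1CC[C@@H]2[C@@H](OC(=O)[C@]23CC(c2ccc(N(C)C)cc2)=NO3)[C@]2(C)C(=O)C=C[C@@]12O` gives 1.51
- compound 2 `C[C@H]1CC[C@@H]2[C@@H](OC(=O)[C@]23CC(c2ccc([N+](=O)[O-])cc2)=NO3)[C@]2(C)C(=O)C=C[C@@]12O` gives 1.37
- compound 3 `COc1cc(C2=NO[C@]3(C2)C(=O)O[C@@H]2[C@H]3CC[C@H](C)[C@]3(O)C=CC(=O)[C@@]23C)ccc1O` gives 0.75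

Compound 3 (0.75) holds the lowest of the three numbers, with compound 2 nearest and compound 1 furthest. The change to compound 4 `C[C@H]1CC[C@@H]2[C@@H](OC(=O)[C@]23CC(c2cccc([N+](=O)[O-])c2)=NO3)[C@]2(C)C(=O)C=C[C@@]12O` is 3-nitrophenyl in place of 4-hydroxy-3-methoxyphenyl on a carbon with a double bond to nitrogen and puts 3-nitrophenyl in place of 4-hydroxy-3-methoxyphenyl on a carbon with a double bond to nitrogen.

The nearest guide is the step between the 4-nitrophenyl and 4-hydroxy-3-methoxyphenyl groups (a number 0.62 log units lower from compound 2 to compound 3 (beyond the scatter)), read in reverse. The step from the 4-(dimethylamino)phenyl compound is of similar size (a number 0.76 log units lower from compound 1 to compound 3 (beyond the scatter)), and the step between the other two aryl groups is small (a number 0.14 log units lower from compound 1 to compound 2 (within the scatter)). Going by the values given here, no measured compound carries 3-nitrophenyl, so the range stays wide.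

A modest rise is expected (a number 0.65 log units higher from compound 3 to compound 4 (beyond the scatter)) in this assay on this reading. The estimate for compound 4 is 1.4 with an expected range of 1.05 to 1.7 for now.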

Compound 4, partition coefficient: 1.37
For compound 4 the middle estimate is 0.03 log units above the measured one; measured number inside the range.
By their numbers in this assay, from the lowest: compound 3; then compounds 2, 4 and 1 (each within the scatter of the next).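

In this assay there is no change at the digits printed from compound 2 to compound 4 (within the scatter) for 3-nitrophenyl in place of 4-nitrophenyl on the carbon with a double bond to nitrogen, so these two aryl groups cannot be told apart here. There is also a number 0.14 log units lower from compound 1 to compound 4 (within the scatter) and so 3-nitrophenyl, 4-nitrophenyl and 4-(dimethylamino)phenyl form one group at this position. Only 4-hydroxy-3-methoxyphenyl stands apart, with a number 0.62 log units higher from compound 3 to compound 4 (beyond the scatter) on this change, and no measurement at hand accounts for that separation.

Which part of the 4-hydroxy-3-methoxyphenyl group goes with the lower number stays open, and plain phenyl, 4-hydroxyphenyl and 4-methoxyphenyl on the same carbon would separate the two substituents. In this assay, from the compounds shown here alone, the reading of an aryl group bearing a carboxylic acid or an amine chain also stays open.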